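From 3,5-dimethylphenyl to 3-cyanophenyl on the shared core

A few compounds are considered here, and "the series" means these few. Any claim that something is new, unique, unknown or untested is made for them only; others in the source may bear on it.

In an ADME assay (liver) for metabolic stability, with Liver microsome (Homo sapiens) as the target, read by LC-MS, using microsomes, with a stated time of 1 h, tested at 5 uM (on this read-out higher numbers stand for a more stable compound and lower numbers for a less stable compound), compound 1 (`Cc1nc(-c2ccccc2F)c(C(=O)N2CCN(c3cc(Cl)cc(Cl)c3)CC2)o1`) stands at 82.3% and compound 2 (`Cc1cc(C)cc(N2CCN(C(=O)c3oc(C)nc3-c3ccccc3)CC2)c1`) at 25.6% as the lower of the two numbers, a gap beyond the scatter. Compound 3 (`Cc1nc(-c2ccccc2)c(C(=O)N2CCN(c3cccc(C#N)c3)CC2)o1`) is still unmeasured. It carries 3-cyanophenyl in place of 3,5-dimethylphenyl on an amine nitrogen in a ring. For the measured compounds named here, no measured pair shows this change alone, so the expectation is loose. An upward step beyond the scatter is expected in this assay and is estimated as a number 29.4 percentage points higher from compound 2 to compound 3 (beyond the scatter) on this basis. The estimate for compound 3 is 55% (expected range 32% to 80%).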

Compound 3, percent of the compound remaining: 8%
For compound 3 the middle estimate is 47 percentage points above the measured one; measured number below the stated range.
By their numbers in this assay, from the lowest: compound 3; then compound 2; then compound 1.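

For the compounds shown here, in the first single-place step, 3-cyanophenyl in place of 3,5-dimethylphenyl on the amine nitrogen gives a number 17.6 percentage points lower from compound 2 to compound 3 (beyond the scatter) in this assay and shows that this position alone can shift the read-out. The step runs downward, so the nitrile-bearing ring does not raise the number on the shared core. Nothing measured here explains the step.

Open, from the compounds shown here alone, is how a methoxy group or a carboxylic acid on this phenyl ring would read. Also open, going by these compounds, is whether this same change gives a step of like size and direction on the core of compound 1.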